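One More Methyl on the Aryl Ketone of Compound 3

The compounds below may be only part of what the source reports. "The series", "measured", "known", "first", "only" and "open" are said of these compounds alone.

Three compounds have been measured in a functional assay on A549 cells (Homo sapiens) for antiproliferative activity, read by MTT assay, with a stated time of 24 h; a higher number here means a weaker inhibitor, a lower number a stronger inhibitor:
compound 1 `COc1ccc(-c2cc(/C=C/C(=O)c3cc(OC)c(OC)c(OC)c3)nc3cc(-c4ccccc4)nn23)cc1OC` gives 7200 nM;
compound 2 `COc1ccc(-c2cc(C(=O)/C=C/c3ccc(Cl)cc3)nc3cc(-c4ccccc4)nn23)cc1OC` gives 22000 nM;
compound 3 `COc1ccc(-c2cc(/C=C/C(=O)c3ccc(C)cc3)nc3cc(-c4ccccc4)nn23)cc1OC` gives 17200 nM.

Compound 3 stands second highest of these three numbers. Its nearest neighbour is compound 2, and the step of a 1.3-fold lower number from compound 2 to compound 3 (0.11 log units; within the scatter) is one the assay cannot tell apart from chance. Its furthest neighbour is compound 1, and the step of a 2.4-fold higher number from compound 1 to compound 3 (0.38 log units; beyond the scatter) is a modest but real loss on going to compound 3.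

Compound 4 `COc1ccc(-c2cc(/C=C/C(=O)c3ccc(C)c(C)c3)nc3cc(-c4ccccc4)nn23)cc1OC` differs from compound 3 by a single change: methyl in place of hydrogen on an aromatic carbon. Among the measured compounds shown here, no measured step adds one small group to the ring in this way; the steps seen so far exchange whole aryl groups or the whole side chain, and even the larger of them, from compound 1 to compound 3, was only modest. A change as small as this one is therefore expected to move the number little, if at all, beyond the scatter. The step of a 1.1-fold lower number from compound 3 to compound 4 (0.06 log units; within the scatter) is the expected outcome. On that basis compound 4 is estimated at 15000 nM, within the range 7000 nM to 33000 nM.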

Compound 4, half-maximal inhibitory concentration: 9300 nM
Estimate against measurement, compound 4: 1.6-fold (0.21 log units) above, and the stated range covers the measured number.
By their numbers in this assay, from the lowest: compounds 1, 4, 3 and 2 (each within the scatter of the next, the first and the last beyond it).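

In this assay, methyl in place of hydrogen on the aromatic ring gives a 1.8-fold lower number from compound 3 to compound 4 (0.27 log units; within the scatter), so this position takes the added methyl with no loss the assay can detect, and no gain can be claimed either. The 3,4-dimethylphenyl group does separate from the side chain of compound 2, with a 2.4-fold lower number from compound 2 to compound 4 (0.37 log units; beyond the scatter), while the exchange for 3,4,5-trimethoxyphenyl gives a 1.3-fold higher number from compound 1 to compound 4 (0.11 log units; within the scatter), so the assay cannot tell those two aryl groups apart here. Nothing available accounts for these steps.

The compounds shown leave open whether a larger group at this place, such as an ethyl or a methoxy, would do as well as methyl. They also leave open what an amine or a carboxylic acid on the same ring would do to the number.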